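Acetylation of a Hydroxy Group: Expectation for Compound 4

The compounds below may be only part of what the source reports. "The series", "measured", "known", "first", "only" and "open" are said of these compounds alone.

Compound 1, `CC(=O)O[C@@H]1C[C@@H](C)[C@](O)(CCC2=CC(=O)OC2)[C@@]2(C)CCCC(C)(C)[C@H]12`, a limit: < 5 ug/mL
Compound 2, `C[C@@H]1C[C@@H](O)[C@H]2C(C)(C)CCC[C@]2(C)[C@@]1(O)CCC1=CC(=O)OC1`, a limit: < 5 ug/mL
Compound 3, `C[C@@H]1C[C@@H](O)[C@H]2C(C)(C)CCC[C@]2(C)[C@@]12CC[C@]1(COC(=O)C1)O2`, a limit: < 5 ug/mL

Of the compounds shown here, three have been tested in a functional assay on ZR-75-30 cells (Homo sapiens) for cytotoxicity, read by MTT assay, with a stated time of 72 h; on this read-out lower numbers stand for stronger inhibition and higher numbers for weaker inhibition. In this assay compound 1 gives < 5 ug/mL, which is a limit of the assay and not a number. Compound 2 gives < 5 ug/mL, likewise a limit. Compound 3 gives < 5 ug/mL, again a limit. All three values sit at the limit of < 5 ug/mL in this assay, at which 3 of the 3 values shown sit, so none of the three is separated from the others.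

Compound 2 and compound 1 differ in one place: acetyl in place of hydrogen on an oxygen on a saturated carbon. The step that the two limits leave unreadable from compound 2 to compound 1. Compound 3 and compound 2 are built from the same atoms joined differently; the difference between the two cores is not broken down here.

Compound 4, `CC(=O)O[C@@H]1C[C@@H](C)[C@]2(CC[C@]3(COC(=O)C3)O2)[C@@]2(C)CCCC(C)(C)[C@H]12`, has not yet been measured. It differs from compound 3 by acetyl in place of hydrogen on an oxygen on a saturated carbon, the same change as that between compound 2 and compound 1, at a place described in the same words.

The step is expected to be a step that the limit leaves unreadable from compound 3 to compound 4, an expectation that rests on the same change having been measured as a step that the two limits leave unreadable from compound 2 to compound 1 with no readable size. Compound 4 is therefore expected to give about 3 ug/mL, between 1 ug/mL and 6 ug/mL, and most likely to return only a limit.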

Compound 4, half-maximal inhibitory concentration: < 5 ug/mL
Compound 4 gave a limit, no number; the forecaster's own chance of this, stated with the estimate: 70%; the middle value lies beyond the limit too.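

In this assay compound 4 gives < 5 ug/mL as a limit of the assay and not a number. Going by these compounds alone, compound 3 also stands at a limit, so no step from compound 3 to compound 4 can be read. The compounds shown leave open how far apart any of these four compounds lie, and whether hydroxy to acetoxy changes the read-out at all.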